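This account rests on a few compounds, and the source may have more. Where it says the series, first, only, none or still open, it means among the compounds named here.

Measured compounds:
Compound 1 `CC[C@H](NC(C)=O)c1cc(Cl)ccc1C1CCN(C(=O)[C@H]2CN(C(C)(C)C)C[C@@H]2c2ccc(F)cc2F)CC1` gives 640 nM in an assay on CHO cells for displacement of a labelled ligand from Melanocortin receptor 4 (Homo sapiens); a lower number here means a stronger inhibitor, a higher number a weaker inhibitor.
Compound 2 `CC[C@H](NC(C)=O)c1cc(Cl)ccc1C1CCN(C(=O)[C@@H]2CN(C(C)(C)C)C[C@H]2c2ccc(F)cc2F)CC1` gives 70 nM in this assay.

Among these two numbers compound 1 stands highest, so it is the weaker binder of the pair; the step of a 9.1-fold lower number from compound 1 to compound 2 (0.96 log units; beyond the scatter) separates it from compound 2, and that step rests on (the fact that compounds 1 and 2 differ only in the configuration as drawn), with the atoms and bonds otherwise unchanged. Compound 3 `CC[C@H](NC(C)=O)c1cc(Cl)ccc1C1CCN(C(=O)[C@H]2CN(C(C)(C)C)C[C@@H]2c2ccc(Cl)cc2Cl)CC1` is built from compound 1 by a change of a different kind: 2,4-dichlorophenyl in place of 2,4-difluorophenyl on a saturated ring carbon. Among the compounds with values here, no measured step involves swapping one halogen for another on that aromatic ring; the only measured step concerns configuration alone, so it gives no guide to the direction or size of the present change. The expectation for compound 3 is therefore kept close to compound 1, with wide uncertainty. Compound 3 is estimated at 500 nM, with a range from 150 nM to 2000 nM. The expected step of a 1.3-fold lower number from compound 1 to compound 3 (0.11 log units; within the scatter) is thus estimated to stay near the usual scatter.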

Compound 3, half-maximal inhibitory concentration: 3.3 nM
Beside the measured number, compound 3's estimate is 150-fold (2.18 log units) above it; the measured number lies below the stated range.
By their numbers in this assay, from the lowest: compound 3; then compound 2; then compound 1.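

At this saturated ring carbon, the identity of the halogens on the aromatic ring matters a great deal: in this assay, 2,4-dichlorophenyl in place of 2,4-difluorophenyl gives a large gain (a 190-fold lower number from compound 1 to compound 3 (2.29 log units; beyond the scatter)). The two groups match in heavy-atom count and in having no hydrogen-bond donors or acceptors, yet this swap moves the number further than the change of configuration alone (a 9.1-fold lower number from compound 1 to compound 2 (0.96 log units; beyond the scatter)). Nothing at hand explains the size of the halogen step.

From the compounds shown here alone, the 2,4-dichlorophenyl group appears here only in the configuration of compound 1, and whether it brings a similar gain in the configuration of compound 2 remains open. Also open, going by these compounds, is how 4-chlorophenyl, 2,4-dibromophenyl or 2,4-dimethylphenyl would behave at this position.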